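Swapping the Ring on the Nitrogen for a Chain

The source may hold more compounds than are shown below. What is called first, only, known or untested is meant among the compounds shown, and "the series" means these compounds.

Three related compounds share one core and were tested in an assay on isolated protein for inhibition of Gonadotropin-releasing hormone receptor (Rattus norvegicus); on this read-out lower numbers stand for stronger inhibition and higher numbers for weaker inhibition. Compound 1 `Cc1cccc(CSc2nc3cc(NC(=O)C4CC4)ccc3n2C(C)C)c1` carries a methylbenzyl group and a cyclopropyl amide; in this assay compound 1 gives > 10000 nM, which is a limit of the assay and not a number. Compound 2 `COc1ccc([N+](=O)[O-])cc1CSc1nc2cc(NC(=O)NC(C)(C)C)ccc2n1C1CC1` carries a tert-butyl urea, a methoxy-nitrobenzyl group and a cyclopropyl on an aromatic nitrogen; in this assay compound 2 gives 860 nM, the higher of the two numbers reported. Compound 3 `CCn1c(SCc2cc([N+](=O)[O-])ccc2OC)nc2cc(NC(=O)NC(C)(C)C)ccc21` differs from compound 2 only in the group on that nitrogen, and in this assay compound 3 gives 170 nM. Within the data shown here, the single measured step, a 5.1-fold lower number from compound 2 to compound 3 (0.70 log units; beyond the scatter), shows that a short open chain in place of the three-membered ring gave the lower number.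

Compound 4 `COCCn1c(SCc2cc([N+](=O)[O-])ccc2OC)nc2cc(NC(=O)NC(C)(C)C)ccc21` has not yet been measured. It differs from compound 2 by 2-methoxyethyl in place of cyclopropyl on an aromatic nitrogen. Among the measured compounds shown here, this is again a ring giving way to a chain, so a move in the same direction as the measured step is expected, though the size is uncertain with only one step to lean on. The expected step is a 2.9-fold lower number from compound 2 to compound 4 (0.46 log units; beyond the scatter). Compound 4 is therefore estimated at 300 nM, within a range from 80 nM to 1200 nM.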

Compound 4, half-maximal inhibitory concentration: 280 nM
The estimate for compound 4 lay 1.1-fold (0.03 log units) above the measured number; the measured number falls inside the stated range.
By their numbers in this assay, from the lowest: compounds 3 and 4 (each within the scatter of the next); then compound 2. At a limit, above all of these: compound 1.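

In this assay, the lower number seen on leaving the cyclopropyl ring is not confined to ethyl, as it also appears with a second open chain, 2-methoxyethyl (a 3.1-fold lower number from compound 2 to compound 4 (0.49 log units; beyond the scatter)). Adding a methoxy to the ethyl chain brings in an oxygen and a hydrogen-bond acceptor, yet compound 3 and compound 4 cannot be told apart on this read-out (a 1.6-fold higher number from compound 3 to compound 4 (0.22 log units; within the scatter)). Among these three compounds, then, the two open chains on the aromatic nitrogen sit together, while the ring stands apart with compound 2.

Going by these compounds, it remains open how far this tolerance extends, since a longer chain such as n-butyl, a chain ending in an amine or a carboxylic acid, or a larger ring such as cyclobutyl could fall on either side, and cyclopropyl is the only ring on this nitrogen to compare with the chains. Nothing among the measurements shown explains why the two chains give lower numbers than the ring.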